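This account rests on a few compounds, and the source may have more. Where it says the series, first, only, none or still open, it means among the compounds named here.

Measured so far in a functional assay on GBM1 cells (Homo sapiens) for antiproliferative activity, read by WST assay, with a stated time of 72 h; on this read-out higher numbers stand for weaker inhibition and lower numbers for stronger inhibition:
- compound 1 `O=C(Nc1cc2ncncc2cc1OCc1ccc(Cl)cc1)Nc1cccc2ccccc12`: 7900 nM
- compound 2 `O=C(Nc1cccc(Cl)c1)Nc1cc2ncncc2cc1OCc1cccc(Cl)c1`: 3300 nM
- compound 3 `O=C(Nc1ccccc1F)Nc1cc2ncncc2cc1OCc1cccc(Cl)c1`: 4200 nM

The number for compound 1 lies within the scatter of compound 3 and beyond the scatter above compound 2.

Compound 4 `O=C(Nc1cc2ncncc2cc1OCc1ccccc1Cl)Nc1cccc2ccccc12` keeps the core of compound 1, with 4-chlorobenzyl changed to 2-chlorobenzyl (2-chlorophenyl in place of 4-chlorophenyl on a saturated chain carbon bound to an oxygen on an aromatic ring). Within the data shown here, no measured step touches this place. Among the measured compounds shown here, the only step available, a 1.3-fold higher number from compound 2 to compound 3 (0.10 log units; within the scatter), concerns an amide-type nitrogen, so it offers weak guidance and gives no reason to expect a large shift. The expected change in this assay is a 1.2-fold lower number from compound 1 to compound 4 (0.08 log units; within the scatter), not beyond the scatter. For compound 4 the estimated value is 6500 nM, with an expected range of 2800 nM to 15000 nM.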

Compound 4, half-maximal inhibitory concentration: 2900 nM
Compound 4: middle estimate off by 2.2-fold (0.35 log units), on the high side; low and high end bracket the measured number.
By their numbers in this assay, from the lowest: compounds 4, 2, 3 and 1 (each within the scatter of the next, the first and the last beyond it).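

Among these compounds, changing 4-chlorobenzyl to 2-chlorobenzyl is the first measured change on a saturated chain carbon bound to an oxygen on an aromatic ring, and in this assay it gives a 2.7-fold lower number from compound 1 to compound 4 (0.44 log units; beyond the scatter) with no change in atom count. The place of the chlorine on this ring alone therefore moves the number beyond the scatter, which the earlier step on an amide-type nitrogen did not do. Nothing measured here accounts for this step.

Open, as far as these compounds go, is whether a methoxy group or an amine in place of the chlorine keeps this step. Also open, from the compounds shown here alone, is whether it holds with 3-chlorophenyl or 2-fluorophenyl on the amide-type nitrogen.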